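Shortening the chain on the most potent urea

A few compounds are considered here, and "the series" means these few. Any claim that something is new, unique, unknown or untested is made for them only; others in the source may bear on it.

Measured compounds, with the result of an assay on microsomes from intestinal mucosa for inhibition of acyl-CoA:cholesterol acyltransferase (Oryctolagus cuniculus); on this read-out lower numbers stand for stronger inhibition and higher numbers for weaker inhibition:
Compound 1, `CCCCCCCC/C=C\CCCCCCCCNC(=O)Nc1c(Cl)cc(Cl)cc1Cl`: 1200 nM
Compound 2, `CCCCCCCC/C=C\CCCCCCCCNC(=O)Nc1cc(C)ccc1C`: 4500 nM
Compound 3, `CCCCCCCC/C=C\CCCCCCCCNC(=O)Nc1c(C)cccc1Cl`: 180 nM

Compound 3 gives the lowest number of the three in this assay: the step of a 6.7-fold lower number from compound 1 to compound 3 (0.82 log units; beyond the scatter) and the step of a 25-fold lower number from compound 2 to compound 3 (1.40 log units; beyond the scatter) both go beyond the scatter, so compound 3 is the strongest inhibitor here. Compound 4, `CCCCCCCCCCCCCCNC(=O)Nc1c(C)cccc1Cl`, keeps the aromatic part of compound 3 unchanged and alters only the long chain: hexyl in place of dec-1-en-1-yl on a saturated chain carbon, eight bonds along the chain from an amide-type nitrogen.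

Among the measured compounds shown here, none of the measured steps bears on this change. The steps of a 3.8-fold higher number from compound 1 to compound 2 (0.57 log units; beyond the scatter), a 6.7-fold lower number from compound 1 to compound 3 (0.82 log units; beyond the scatter) and a 25-fold lower number from compound 2 to compound 3 (1.40 log units; beyond the scatter) all swap substituents on the aromatic ring while the chain stays the same, so they say nothing about a shorter, saturated chain. With no comparison to lean on, the expectation is a modest weakening at most, possibly no step beyond the scatter, and the uncertainty is wide.

Compound 4 is therefore estimated at 350 nM, with a likely range from 100 nM to 1500 nM. For compound 4 the expected step is then a 1.9-fold higher number from compound 3 to compound 4 (0.29 log units; within the scatter).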

Compound 4, half-maximal inhibitory concentration: 70 nM
Estimate against measurement, compound 4: 5.0-fold (0.70 log units) above; the whole stated range lies above it.
By their numbers in this assay, from the lowest: compound 4; then compound 3; then compound 1; then compound 2.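

In this assay, the long chain proves to be a place where change is tolerated: hexyl in place of dec-1-en-1-yl gives a 2.6-fold lower number from compound 3 to compound 4 (0.41 log units; beyond the scatter), a step beyond the scatter towards stronger inhibition. The earlier compounds shown here varied only the aromatic ring, whereas this result shows that, with this aromatic part, neither the double bond nor the four extra chain carbons of compound 3 are needed for inhibition. The data shown offer no measured explanation for the stronger inhibition by the shorter, saturated chain.

As far as these compounds go, this single change removes the double bond and shortens the chain together, so their separate contributions remain unknown; a saturated decyl group at this place would help to tell them apart. From the compounds shown here alone, how a butyl group, or a chain ending in a carboxylic acid or an amine, would behave also remains open.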